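Replacing the triazole side chain of compound 1

The source may report more compounds than this note shows. Statements on the series, on what has been measured and on what is new or still open speak of the compounds shown alone.

Measured in a functional assay on A549 cells (Homo sapiens) for cytotoxicity, read by MTT assay, with a stated time of 72 h; on this read-out higher numbers stand for weaker inhibition and lower numbers for stronger inhibition:
- compound 1 `O=C1c2c[n+]([O-])c3ccccc3c2C(=O)c2c1c1ccccc1n2Cc1cn(CC(O)CO)nn1`: 880 nM
- compound 2 `CC1(C)O[C@@H](CO)[C@H](Cn2cc(Cn3c4c(c5ccccc53)C(=O)c3c[n+]([O-])c5ccccc5c3C4=O)nn2)O1`: 370 nM
- compound 3 `CC1(C)OC[C@H](Cn2cc(Cn3c4c(c5ccccc53)C(=O)c3c[n+]([O-])c5ccccc5c3C4=O)nn2)O1`: 340 nM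

Compound 1 has the highest number of the three, so it is the weakest in this assay. Compound 4 `CCCN1CCN(CCCCn2c3c(c4ccccc42)C(=O)c2c[n+]([O-])c4ccccc4c2C3=O)CC1` has not yet been measured. It departs from compound 1 by 3-(4-propylpiperazin-1-yl)propyl in place of 1-(2,3-dihydroxypropyl)-1H-1,2,3-triazol-4-yl on a saturated chain carbon bound to an aromatic nitrogen. For the measured compounds named here, the only measured steps that bear on this change alter the same side chain, and both lead to lower numbers: a 2.4-fold lower number from compound 1 to compound 2 (0.38 log units; beyond the scatter) and a 2.6-fold lower number from compound 1 to compound 3 (0.41 log units; beyond the scatter). Compound 2 and compound 3 do not separate, at a 1.1-fold lower number from compound 2 to compound 3 (0.04 log units; within the scatter). Going by the values given here, both of those steps keep the triazole, whereas compound 4 loses it, so they serve only as a loose guide, and no measured compound carries a piperazine. A step in the same direction, somewhat larger and quite uncertain, is therefore expected: a 3.5-fold lower number from compound 1 to compound 4 (0.55 log units; beyond the scatter). Compound 4 is estimated at 250 nM, with an expected range of 70 nM to 900 nM.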

Compound 4, half-maximal inhibitory concentration: 320 nM
Estimate against measurement, compound 4: 1.3-fold (0.11 log units) below, within the range that was stated.
By their numbers in this assay, from the lowest: compounds 4, 3 and 2 (each within the scatter of the next); then compound 1.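

In this assay, the triazole is not required at this position, the saturated chain carbon bound to an aromatic nitrogen: with 3-(4-propylpiperazin-1-yl)propyl in its place, which has no five-membered aromatic ring and no hydrogen-bond donors, the result is a 2.8-fold lower number from compound 1 to compound 4 (0.44 log units; beyond the scatter). Until now, every lower number at this position had come with the triazole retained, whereas compound 4 now stands within the scatter of compound 3 without it. No evidence is available to explain this step.

Going by these compounds, whether the step depends on the piperazine ring, its propyl group or the chain remains open, since compound 4 changes all of them together. It is also unknown how a morpholine or a dimethylamine at the end of the same chain would compare.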